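From 4-hydroxyphenyl to 3-methoxyphenyl on the amine

The source may hold more compounds than are shown below. What is called first, only, known or untested is meant among the compounds shown, and "the series" means these compounds.

Within the data shown here, in a functional assay on KB cells (Homo sapiens) for cytotoxicity, read by sulforhodamine B assay (a higher number here means a weaker inhibitor, a lower number a stronger inhibitor), compound 2 `C=C1[C@@H](OC(C)=O)C[C@@H]2[C@](C)(CO[Si](C)(C)C(C)(C)C)[C@H](OC(C)=O)CC[C@@]2(C)[C@@H]1C[C@@H](Nc1ccc(O)cc1)C1=CCOC1=O` gives 8350 nM, while its only measured neighbour, compound 1 `C=C1[C@@H](OC(C)=O)C[C@@H]2[C@](C)(CO[Si](C)(C)C(C)(C)C)[C@H](OC(C)=O)CC[C@@]2(C)[C@@H]1C[C@@H](Nc1ccc(F)cc1)C1=CCOC1=O` gives 5090 nM. These two results cannot be told apart. Compound 3 `C=C1[C@@H](OC(C)=O)C[C@@H]2[C@](C)(CO[Si](C)(C)C(C)(C)C)[C@H](OC(C)=O)CC[C@@]2(C)[C@@H]1C[C@@H](Nc1cccc(OC)c1)C1=CCOC1=O` keeps the shared core but has 3-methoxyphenyl in place of 4-hydroxyphenyl on an amine nitrogen. Among the measured compounds shown here, one measured step bears on this change: a 1.6-fold higher number from compound 1 to compound 2 (0.21 log units; within the scatter), which put hydroxy in place of fluoro on an aromatic carbon. For the measured compounds named here, that step altered only one group on the aromatic ring, and its size stayed within the scatter. Going by the values given here, no measured compound carries a methoxy group, so this evidence is thin. A step beyond the scatter is therefore not expected in this assay, and no direction can be claimed with confidence. The estimated change is a 1.3-fold lower number from compound 2 to compound 3 (0.11 log units; within the scatter). For compound 3, the estimated value is 6500 nM, with an expected range from 2800 nM to 15000 nM.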

Compound 3, half-maximal inhibitory concentration: 45200 nM
Compound 3: the middle estimate sits 7.0-fold (0.84 log units) below what was measured; measured number outside the range, above it.
By their numbers in this assay, from the lowest: compounds 1 and 2 (each within the scatter of the next); then compound 3.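

The aromatic group on the amine nitrogen matters more in this assay than compounds 1 and 2 suggested. The steps of a 5.4-fold higher number from compound 2 to compound 3 (0.73 log units; beyond the scatter) and an 8.9-fold higher number from compound 1 to compound 3 (0.95 log units; beyond the scatter) both lie beyond the scatter, whereas hydroxy in place of fluoro had stayed within it. This position can therefore move the number, and 3-methoxyphenyl moves it towards a weaker inhibitor, but nothing available explains this loss.

Compound 3 differs from compounds 1 and 2 both in its ring substituent and in where that substituent sits, so these two changes cannot be separated. Open questions are whether 4-methoxyphenyl or 3-hydroxyphenyl on the same nitrogen would give a number closer to compound 2 or to compound 3, and how a plain phenyl would compare.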